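A few compounds are considered here, and "the series" means these few. Any claim that something is new, unique, unknown or untested is made for them only; others in the source may bear on it.

Series notes. Compound 1 `COc1cc(/C=C/c2cc(C)no2)ccc1O`, compound 2 `Cc1cc(/C=C/c2ccc(O)cc2)on1` and compound 3 `Cc1cc(/C=C/c2ccc(O)c(O)c2)[nH]n1` are the measured members. In a functional assay on MDA-MB-231 cells (Homo sapiens) for cytotoxicity, read by MTT assay, with a stated time of 72 h (on this read-out lower numbers stand for stronger inhibition and higher numbers for weaker inhibition), compound 1 gives 34600 nM, compound 2 gives 55500 nM and compound 3 gives 56700 nM. Compound 2 stands second highest of the three numbers; its nearest neighbour is compound 3 and its furthest is compound 1, and both gaps lie within the scatter, so no order among the three can be read. Among the compounds with values here, the one step joining measured compounds is a 1.6-fold higher number from compound 1 to compound 2 (0.21 log units; within the scatter), within the scatter.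

Compound 4 `Cc1cc(/C=C/c2ccc(O)c(O)c2)on1` differs from compound 2 by hydroxy in place of hydrogen on an aromatic carbon. Within the data shown here, the only measured step that bears on this change, the removal of methoxy in going from compound 1 to compound 2, left this assay unmoved; no measured step adds a hydroxy, and compound 3 carries the same two hydroxy groups on a different core without departing from compound 2. The expected step of a 1.1-fold lower number from compound 2 to compound 4 (0.05 log units; within the scatter) is therefore none beyond the scatter. Compound 4 is estimated at 50000 nM, within 22000 nM to 110000 nM.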

Compound 4, half-maximal inhibitory concentration: 8900 nM
Beside the measured number, compound 4's estimate is 5.6-fold (0.75 log units) above it; the whole stated range lies above it.
By their numbers in this assay, from the lowest: compound 4; then compounds 1, 2 and 3 (each within the scatter of the next).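

In this assay, this place on the six-membered ring proves sensitive to what it carries: hydroxy in place of hydrogen gives a 6.2-fold lower number from compound 2 to compound 4 (0.79 log units; beyond the scatter), the first sign of a real difference within the series. Methoxy does not match hydroxy here, as removing the methyl from that oxygen gives a 3.9-fold lower number from compound 1 to compound 4 (0.59 log units; beyond the scatter), whereas swapping methoxy for hydrogen gives only a 1.6-fold higher number from compound 1 to compound 2 (0.21 log units; within the scatter), within the scatter. No measurement at hand accounts for this difference.

On these data alone, compound 3 carries the same two hydroxy groups on another core and gives 56700 nM, but it has no partner lacking the second hydroxy, so whether the step holds beyond the core of compound 4 remains open. Also open, as far as these compounds go, is whether only hydroxy serves at this place, or whether an amine or a carboxylic acid would give a similar number.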